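This account rests on a few compounds, and the source may have more. Where it says the series, first, only, none or still open, it means among the compounds named here.

Measured in a functional assay on NCI/ADR-RES cells (Homo sapiens) for cytotoxicity; on this read-out lower numbers stand for stronger inhibition of growth and higher numbers for weaker inhibition of growth:
- compound 1 `COc1ccc(NS(=O)(=O)c2c(F)c(F)c(F)c(Br)c2F)cc1`: 190 nM
- compound 2 `COc1ccc(NS(=O)(=O)c2ccc(F)c(F)c2F)cc1`: > 50000 nM (a limit)

Among the compounds with values here, compound 1 carries the only actual number so far, at 190 nM. Compound 2 gives > 50000 nM, which is a limit and not a number. Within the data shown here, the two values show measurable growth inhibition for compound 1 and only a limit for compound 2, so the series offers no numeric step to work from.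

Next in line is compound 3 `COc1ccc(NS(=O)(=O)c2c(F)c(F)c(F)c(F)c2F)cc1`, not yet measured in this assay. It differs from compound 1 by one change, fluoro in place of bromo on an aromatic carbon. That carbon is ortho to two fluoro groups, meta to a fluoro group, meta to a large group and para to a fluoro group. Among the measured compounds shown here, no measured pair isolates this exchange, so the expectation rests on compound 1 at 190 nM alone, and no shift beyond the scatter is expected. The expected 1.3-fold lower number from compound 1 to compound 3 (0.10 log units; within the scatter) is a small one, with direction left open. Compound 3 is estimated at 150 nM, with an expected range of 40 nM to 600 nM.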

Compound 3, concentration for 50% growth inhibition: 58 nM
Beside the measured number, compound 3's estimate is 2.6-fold (0.41 log units) above it; the measured number falls inside the stated range.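

In this assay the series now has its first readable step, a 3.3-fold lower number from compound 1 to compound 3 (0.52 log units; beyond the scatter) on exchanging bromo for fluoro at the aromatic carbon that is para to a fluoro group. Bromo is therefore not required at this place for growth inhibition in these cells, and compound 3 keeps the activity seen with compound 1 while carrying fluoro there. A swap of one single-atom halogen for another, with no ring and no net charge entering or leaving, is enough to move the number beyond the scatter, although no measurement shown gives a reason for this step.

On these data alone, whether chloro, iodo or an amine on the same carbon would give a lower or a higher number than fluoro and bromo stays open, since this single pair gives no trend across substituents at this position. Compound 2 gives only a limit and not a number, so no step involving it can be read: the limit of > 50000 nM in this assay, at which 1 of the 3 values shown sits.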